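Chain-end variations on a shared phenol core

The compounds below may be only part of what the source reports. "The series", "measured", "known", "first", "only" and "open" are said of these compounds alone.

Three measured compounds share one core and differ only at the end of the chain hanging from the aromatic oxygen. Compound 1, `C=CCc1cc(C(C)=O)c(O)cc1OCCCCCCC#N`, gives 97% in an assay on isolated protein for inhibition of leukotriene B4 receptor 1 (Homo sapiens), tested at 10 uM; a lower number here means less inhibition, a higher number more inhibition at the concentration tested (going by the name of the read-out). Compound 2, `C=CCc1cc(C(C)=O)c(O)cc1OCCCCCCCC#N`, gives 88% in this assay. Compound 3, `C=CCc1cc(C(C)=O)c(O)cc1OCCCCCC(=O)NO`, gives 85% in this assay; its number is the lowest of the three as written, though the gap to compound 2 is within the scatter, while the step of a number 12 percentage points lower from compound 1 to compound 3 (beyond the scatter) is beyond it and modest. The step of a number 9 percentage points lower from compound 1 to compound 2 (within the scatter) and the step of a number 3 percentage points lower from compound 2 to compound 3 (within the scatter) both stay within the scatter, so every change at the chain end so far has moved the read-out little.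

Compound 4, `C=CCc1cc(C(C)=O)c(O)cc1OCCCCCC(=O)N(C)C`, is compound 3 with dimethylamino in place of hydroxyamino on a carbonyl carbon. Among the compounds with values here, no measured step makes this exact exchange; the three chain-end steps are the only guide, and none exceeded a modest size. The expected step of a number 7 percentage points lower from compound 3 to compound 4 (within the scatter) in this assay is therefore small, with a slight lean downward in line with the step of a number 12 percentage points lower from compound 1 to compound 3 (beyond the scatter). Compound 4 is thus estimated to give 78% in this assay, with a range from 55% to 95%.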

Compound 4, a percentage reported as inhibition, at one concentration (the size of the read-out at that concentration, not a potency): 92%
Compound 4: middle estimate off by 14 percentage points, on the low side; low and high end bracket the measured number.
By their numbers in this assay, from the lowest: compounds 3, 2, 4 and 1 (each within the scatter of the next, the first and the last beyond it).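

Hydroxyamino carries hydrogen-bond donors and dimethylamino carries none, yet this assay records a number 7 percentage points higher from compound 3 to compound 4 (within the scatter) at this carbonyl carbon, so these donors are not required for a high number at the concentration tested. The steps of a number 4 percentage points higher from compound 2 to compound 4 (within the scatter) and a number 5 percentage points lower from compound 1 to compound 4 (within the scatter) also leave dimethylcarbamoyl within the scatter of both nitrile chain ends in this assay as well, and a number 12 percentage points lower from compound 1 to compound 3 (beyond the scatter) remains the only step among these four compounds that lies beyond the scatter. No measurement available here explains why this exchange moves the number so little.

The compounds shown leave open whether a chain end such as a carboxylic acid, a primary amide or an amine would hold a number this high, and whether a much shorter chain would do so too. All four compounds were read at a single concentration, which gives no potency, so a full concentration series would be needed to show whether these chain ends truly match one another or differ in a way this read-out cannot reveal.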